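The source may hold more compounds than are shown below. What is called first, only, known or untested is meant among the compounds shown, and "the series" means these compounds.

Of the compounds shown here, three have so far been tested in an assay for positive allosteric modulation of metabotropic glutamate receptor 3 (Rattus norvegicus); on this read-out lower numbers stand for an effect already at smaller amounts and higher numbers for an effect only at larger amounts of compound. Compound 1 `COc1ccc(OCCCCOc2ccc(C(=O)CC(C)(C)C)c(O)c2C)cc1` gives "not active" (no number reported), and compound 2 `Cc1c(OCCCCOc2ccc(F)c(C(N)=O)c2)ccc(C(=O)CC(C)(C)C)c1O` gives "not active" (no number reported). Within the data shown here, compound 3 `Cc1c(OC[C@@H](C)COc2ccc(F)c(C(=O)O)c2)ccc(C(=O)CC(C)(C)C)c1O` is the only one with a measured number, at 1180 nM, so it stands alone here and no ranking against the other two is possible. Compound 4 `COc1ccccc1OC[C@H](C)COc1ccc(C(=O)CC(C)(C)C)c(O)c1C` differs from compound 3 in one place: 2-methoxyphenyl in place of 3-carboxy-4-fluorophenyl on an oxygen on a saturated carbon. Among the measured compounds shown here, no step between two measured compounds is known, so the size of this change cannot be read from the data. Compound 4 is nevertheless expected to weaken, with a step of a 3.8-fold higher number from compound 3 to compound 4 (0.58 log units; beyond the scatter) beyond the usual scatter, because compound 2 gives "not active" (no number reported) once the carboxylic acid is gone. Compound 4 is estimated at 4500 nM, between 1200 nM and 20000 nM, with a real chance that only inactivity is reported.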

Compound 4, half-maximal effective concentration: "not active" (no number reported)
No number was reported for compound 4, and the estimate cannot be compared.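

Among these compounds, with no number for compound 4, no step from compound 3 can be read. Nothing shown here offers an explanation for this result. On these data alone, what stays open is how large a change the swap to 2-methoxyphenyl makes.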